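Turning one double bond from E to Z

A few compounds are considered here, and "the series" means these few. Any claim that something is new, unique, unknown or untested is made for them only; others in the source may bear on it.

Measured so far in a functional assay on DU-145 cells (Homo sapiens) for antiproliferative activity, read by WST assay, with a stated time of 72 h; on this read-out lower numbers stand for an effect already at smaller amounts and higher numbers for an effect only at larger amounts of compound
Compound 1 `CCCCCCCCCCc1c(C)c(CCCCCCCCCC)c2[n+](c1C)CCC2` gives 1.3 uM
Compound 2 `CCCCCCCC/C=C/c1c(C)c(/C=C/CCCCCCCC)c2[n+](c1C)CCC2` gives 0.8 uM

In this assay compound 2 stands at 0.8 uM and compound 1 at 1.3 uM and these two values lie within the usual scatter of each other, so neither can be ranked over the other.

Compound 3 `CCCCCCCC/C=C\c1c(C)c(/C=C/CCCCCCCC)c2[n+](c1C)CCC2` has not yet been measured. Its relation to compound 2 is simple: the two compounds have the same atoms and bonds and differ only in configuration as drawn: 1 of 2 stereo elements differ; a double bond is drawn E in compound 2 and Z in compound 3 and nothing else separates them.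

Among the compounds with values here, no measured pair in this set differs in one place only, so the data show nothing directly about what such a change of configuration does. Within the data shown here, the only guide is the closeness of the two values in hand, with compound 1 at 1.3 uM and compound 2 at 0.8 uM in the same range. No shift beyond the scatter is therefore expected in either direction in this assay and the estimate is a 1.1-fold higher number from compound 2 to compound 3 (0.05 log units; within the scatter) as a step of small size. Compound 3 is estimated at 0.9 uM with values between 0.4 uM and 2 uM as its expected range.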

Compound 3, concentration for half-maximal effect: 0.2 uM
Compound 3: the middle estimate sits 4.5-fold (0.65 log units) above what was measured; the measured number lies below the stated range.
By their numbers in this assay, from the lowest: compound 3; then compounds 2 and 1 (each within the scatter of the next).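

In this assay, the step of a 4.0-fold lower number from compound 2 to compound 3 (0.60 log units; beyond the scatter) is the only one in this set that isolates a single change, and it shows that the configuration of one of the two double bonds is not silent on this read-out. The shift can be tied to that configuration alone, because no other structural difference separates the pair: the fact that compounds 2 and 3 differ only in the configuration as drawn. The earlier compounds shown here offered no pair differing in one place, so this sensitivity to the drawn geometry could not be seen from them, and it still rests on this one pair.

On these data alone, it remains open whether drawing the second double bond Z as well would move the number further, or whether the effect depends on which of the two double bonds is changed. Also open, as far as these compounds go, is whether a longer chain, or a chain carrying an amine or a carboxylic acid, would keep the number that compound 3 gives, 0.2 uM, in this assay.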